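Trading a fluoropyridine for a methylpyridine on the ether carbon

The source may report more compounds than this note shows. Statements on the series, on what has been measured and on what is new or still open speak of the compounds shown alone.

Of the compounds shown here, three with a shared acid-bearing core have been measured in an assay on HEK293 cells for inhibition of kynurenine 3-monooxygenase (Homo sapiens), read by LC-MS, with a stated time of 20 h; on this read-out lower numbers stand for stronger inhibition and higher numbers for weaker inhibition. Compound 1 `C[C@@H](Oc1cc2onc(CCC(=O)O)c2cc1Cl)c1ccc(F)cn1` gives 31.6 nM. Compound 2 `C[C@@H](Oc1cc2oc(=O)n(CCC(=O)O)c2cc1Cl)c1ccc(F)cn1`, which carries a different core with the same side groups, gives 25.1 nM, a number within the scatter of compound 1. Compound 3 `Cc1ccc([C@@H](C)Oc2cc3onc(CCC(=O)O)c3cc2Cl)nn1` gives 3.16 nM and stands apart: the step of a 10-fold lower number from compound 1 to compound 3 (1.00 log units; beyond the scatter) is the only one here that goes beyond the scatter. On the numbers shown, compound 2 sits second highest, close to compound 1 and well above compound 3.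

The next compound, compound 4 `Cc1cccc([C@@H](C)Oc2cc3oc(=O)n(CCC(=O)O)c3cc2Cl)n1`, keeps the core of compound 2 and differs from it in one place: 6-methylpyridin-2-yl in place of 5-fluoropyridin-2-yl on a saturated chain carbon bound to an oxygen on an aromatic ring and a saturated chain carbon.

Among the measured compounds shown here, the only measured step that bears on this is the one from compound 1 to compound 3, where a 6-methylpyridazin-3-yl replaced the same 5-fluoropyridin-2-yl and the number fell by a 10-fold lower number from compound 1 to compound 3 (1.00 log units; beyond the scatter). The new group in compound 4 shares the methyl but not the second ring nitrogen, so a similar change, perhaps smaller, is expected. For compound 4 the expected step is a 4.0-fold lower number from compound 2 to compound 4 (0.60 log units; beyond the scatter) in this assay. Compound 4 is therefore estimated at 6.3 nM, with a likely range from 2 nM to 20 nM.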

Compound 4, half-maximal inhibitory concentration: 316 nM
Estimate against measurement, compound 4: 50-fold (1.70 log units) below, and the stated range ends below it.
By their numbers in this assay, from the lowest: compound 3; then compounds 2 and 1 (each within the scatter of the next); then compound 4.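

In this assay, the step of a 13-fold higher number from compound 2 to compound 4 (1.10 log units; beyond the scatter) shows that a methyl-bearing ring at this position does not have to lower the number: here it goes the opposite way from a 10-fold lower number from compound 1 to compound 3 (1.00 log units; beyond the scatter). The position on the saturated chain carbon is therefore sensitive to more than the presence of a methyl, since 5-fluoropyridin-2-yl and 6-methylpyridin-2-yl match in heavy atoms, hydrogen-bond donors and acceptors and in having one six-membered aromatic ring, yet the change is large. No measurement shown here explains why this swap raises the number.

As far as these compounds go, the two steps differ both in the incoming ring and in the core, so it remains open whether the opposite directions follow from the ring, from the core or from the two together, a question that 6-methylpyridazin-3-yl on the core of compound 2 and 6-methylpyridin-2-yl on the core of compound 1 would help to settle. A plain pyridin-2-yl, carrying neither methyl nor fluorine, would also help separate what the methyl adds from what the loss of fluorine takes away.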